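The source may hold more compounds than are shown below. What is called first, only, known or untested is meant among the compounds shown, and "the series" means these compounds.

Among the compounds with values here, in a functional assay on NCI-H460 cells (Homo sapiens) for cytotoxicity, read by MTT assay, with a stated time of 48 h (on this read-out higher numbers stand for weaker inhibition and lower numbers for stronger inhibition), compound 3 `C=C1C(=O)O[C@H]2CC3=C[C@H](C/C(C)=C/[C@@H](OC(=O)CC4CCCCC4)[C@H]12)OC3=O` gives 2000 nM and holds the only true number so far. Compound 1 `C=C1C(=O)O[C@H]2CC3=C[C@H](C/C(C)=C/[C@@H](OC(=O)c4ccc(C(F)(F)F)cc4)[C@H]12)OC3=O` sits at > 10000 nM and this is a limit of the assay, not a number. Compound 2 `C=C1C(=O)O[C@H]2CC3=C[C@H](C/C(C)=C/[C@@H](OC(=O)CCl)[C@H]12)OC3=O` sits at > 10000 nM and this too is a limit.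

Compound 4 `C=C1C(=O)O[C@H]2CC3=C[C@H](C/C(C)=C/[C@@H](OC(=O)/C=C/c4ccncc4)[C@H]12)OC3=O` keeps the shared core and changes one group: 2-(pyridin-4-yl)ethenyl in place of cyclohexylmethyl on a carbonyl carbon is the full difference, with 2-(pyridin-4-yl)ethenyl in place of cyclohexylmethyl on a carbonyl carbon. Within the data shown here, two measured steps bear on this change: an at least 5.0-fold lower number from compound 1 to compound 3 (0.69 log units; beyond the scatter) and an at least 5.0-fold lower number from compound 2 to compound 3 (0.69 log units; beyond the scatter) are both open-ended, so each gives only a lower bound on size.

Compound 1 is the nearer comparison, as its acyl group also bears an aromatic ring. Compound 2 goes against tying the limit to such a ring, since its chloromethyl group has none. Reading an at least 5.0-fold lower number from compound 1 to compound 3 (0.69 log units; beyond the scatter) in reverse, a modest move toward weaker inhibition in this assay is expected, and the result may reach the limit of the assay. The expected size is a 2.3-fold higher number from compound 3 to compound 4 (0.35 log units; beyond the scatter) in this estimate. For compound 4 the estimated value is 4500 nM with an expected range from 1200 nM to 12000 nM on repeat measurement.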

Compound 4, half-maximal inhibitory concentration: 2100 nM
For compound 4 the middle estimate is 2.1-fold (0.33 log units) above the measured one; the range from low to high includes it.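

In this assay, the acyl group on the carbonyl carbon can carry an aromatic ring and still give a true number: a 1.1-fold higher number from compound 3 to compound 4 (0.02 log units; within the scatter), so 2-(pyridin-4-yl)ethenyl and cyclohexylmethyl cannot be told apart at this position. An aromatic ring in the acyl group is therefore not enough on its own to bring a compound to the limit, with compound 4 going against that reading of compound 1, and chloromethyl in compound 2 showing that such a ring is not needed for the limit either. The two further steps, an at least 4.7-fold lower number from compound 2 to compound 4 (0.67 log units; beyond the scatter) and an at least 4.7-fold lower number from compound 1 to compound 4 (0.67 log units; beyond the scatter), are open-ended and give only a lower bound on size: the limit of > 10000 nM in this assay, at which 2 of the 4 values shown sit.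

A 2-phenylethenyl group or a saturated 2-(pyridin-4-yl)ethyl chain on the same carbonyl carbon would be needed to separate the part of the ring nitrogen from that of the double bond, and these compounds leave that open. Also open, from the compounds shown here alone, is how an acyl group bearing an amine or a carboxylic acid would read at this position.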